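The source may report more compounds than this note shows. Statements on the series, on what has been measured and on what is new or still open speak of the compounds shown alone.

Measured in a functional assay on ACHN cells (Homo sapiens) for cytotoxicity, read by sulforhodamine B assay, with a stated time of 72 h; a lower number here means a stronger inhibitor of growth, a higher number a weaker inhibitor of growth:
- compound 1 `O=C(Nc1cc(C(F)(F)F)cc(C(F)(F)F)c1)C1CCc2ccccc2N1C(=O)c1ccccc1Cl`: 4700 nM
- compound 2 `O=C(Nc1ccccc1C(F)(F)F)C1CCc2ccccc2N1`: 57600 nM
- compound 3 `O=C(Nc1ccccc1O)C1CCc2ccccc2N1`: 3990 nM

Compound 1 is second highest of these three numbers. It lies within the scatter of compound 3, while compound 2 gives a much higher number. The next compound to be tested, compound 4 `O=C(Nc1cc(C(F)(F)F)cc(C(F)(F)F)c1)C1CCc2ccccc2N1C(=O)c1cccc(Cl)c1`, differs from compound 1 by 3-chlorophenyl in place of 2-chlorophenyl on a carbonyl carbon, which is 3-chlorophenyl in place of 2-chlorophenyl on a carbonyl carbon. Among the compounds with values here, only one measured step between closely matched compounds is available, a 14-fold lower number from compound 2 to compound 3 (1.16 log units; beyond the scatter). That step is large, but it is hydroxy in place of trifluoromethyl on an aromatic carbon, and neither compound carries a chlorophenyl group. It therefore offers no direct guide, and no measurement here tests this kind of change. With no evidence for a direction, no shift beyond the scatter is expected in this assay, though the uncertainty is wide. The expected step is a 1.0-fold lower number from compound 1 to compound 4 (0.02 log units; within the scatter). The estimate for compound 4 is 4500 nM, with an expected range from 1600 nM to 12500 nM.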

Compound 4, concentration for 50% growth inhibition: 813 nM
Compound 4: middle estimate off by 5.5-fold (0.74 log units), on the high side, outside the stated range (below it).
By their numbers in this assay, from the lowest: compound 4; then compounds 3 and 1 (each within the scatter of the next); then compound 2.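

In this assay, the change from (2-chlorophenyl)carbonyl to (3-chlorophenyl)carbonyl gives a 5.8-fold lower number from compound 1 to compound 4 (0.76 log units; beyond the scatter) and so shows that this place on the shared core responds to where the chlorine stands on the phenyl ring. Within the data shown here, the two groups have the same atoms and the same counts, so this pair isolates the placement of the chlorine, which no earlier pair of compounds could do. Nothing measured here accounts for the difference between the two placements.

The compounds shown leave open whether a group other than chlorine, such as methoxy, nitrile or an amine, would give a similar number on this phenyl ring. They also leave open whether the same step would appear with a different group on the other amide, since this pair carries only the two trifluoromethyl groups.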